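A few compounds are considered here, and "the series" means these few. Any claim that something is new, unique, unknown or untested is made for them only; others in the source may bear on it.

Compound 1 `Cc1cccc(NC(=O)c2cccc(/C=C3\CC(=O)N(c4ccccc4)C3=O)c2)c1` in an ADME assay on NCM460 cells (Homo sapiens) for cytotoxicity, read by MTT assay, with a stated time of 72 h; a lower number here means a stronger inhibitor, a higher number a weaker inhibitor: > 100000 nM
Compound 2 `CCCCCN1C(=O)C/C(=C\c2cccc(C(=O)NCCCC)c2)C1=O` in this assay: > 100000 nM

The value for compound 1 is a limit of the assay, not a measured number. The value for compound 2 is likewise only a limit. Compound 1 therefore cannot be ranked against anything here; it sits at the limit of > 100000 nM in this assay, at which 2 of the 2 values shown sit, and neither compound gave a number to compare.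

Compound 3 `O=C(c1cccc(/C=C2\CC(=O)N(c3ccccc3)C2=O)c1)N1CCCC1` differs from compound 1 by one change: pyrrolidin-1-yl in place of (3-methylphenyl)amino on a carbonyl carbon. Among the measured compounds shown here, no pair of measured compounds differing in a single place exists, so the effect of this change has not been seen. With compound 1 resting at its limit > 100000 nM, the expectation for compound 3 in this assay is no step beyond the usual scatter, in either direction, so that a step that the limit leaves unreadable from compound 1 to compound 3 is expected to be small. The estimate for compound 3 is 150000 nM, expected to fall between 50000 nM and 400000 nM, most likely reported again as a limit.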

Compound 3, half-maximal inhibitory concentration: > 100000 nM
Compound 3 ended at the assay's limit; the forecaster's own chance of this, stated with the estimate: 75%; the middle value is on the limit's open side.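

In this assay, among the compounds shown here, compound 3 gives only a limit, just as compound 1 does, so no step between the two can be read: the limit of > 100000 nM in this assay, at which 3 of the 3 values shown sit. The compounds shown leave open how pyrrolidin-1-yl and (3-methylphenyl)amino compare on that carbonyl carbon, and which change, if any, would give a measurable number.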